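Replacing the 4-methyl-3-nitrophenyl group of compound 1

A few compounds are considered here, and "the series" means these few. Any claim that something is new, unique, unknown or untested is made for them only; others in the source may bear on it.

Among the measured compounds shown here, in a physicochemical assay for lipophilicity, using the shake flask method, measured as octanol-water partition (a lower number here means a more polar compound, a higher number a more lipophilic compound), compound 1 (`COc1ccc(Cl)cc1-n1ncc(-c2nnc(-c3ccc(C)c([N+](=O)[O-])c3)o2)c1C`) gives 6.42 as the higher of the two numbers measured so far, and compound 2 (`COc1ccc(Cl)cc1-n1ncc(-c2nnc(-c3ccccc3)o2)c1C`) gives 4.32 as the lower. Compound 3 (`COc1ccc(Cl)cc1-n1ncc(-c2nnc(-c3ccc(Cl)cc3)o2)c1C`) has not been measured yet. The change from compound 1 to compound 3 is 4-chlorophenyl in place of 4-methyl-3-nitrophenyl on an aromatic carbon. For the measured compounds named here, the one measured step that bears on this removes the same group from the same place and brings in phenyl, and it gives a number 2.10 log units lower from compound 1 to compound 2 (beyond the scatter) as its large result. Compound 3 differs from compound 2 (4.32 as its value) by keeping a chlorine on that ring, so a lower number is expected again, but a smaller drop. The expected step, an estimate, is a number 1.42 log units lower from compound 1 to compound 3 (beyond the scatter) in the same direction. Compound 3 is thus expected at 5 within an estimated range from 4.5 to 5.6 for now.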

Compound 3, partition coefficient: 4.51
Compound 3: middle estimate off by 0.49 log units, on the high side; the range from low to high includes it.
By their numbers in this assay, from the lowest: compounds 2 and 3 (each within the scatter of the next); then compound 1.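

In this assay a second replacement in this place, 4-chlorophenyl, gives a number 1.91 log units lower from compound 1 to compound 3 (beyond the scatter) and so shows that the large step seen with phenyl was not a single case: of the three compounds, only compound 1, with its 4-methyl-3-nitrophenyl group, stands apart at the high end. Chloro in place of hydrogen on the phenyl ring gives a number 0.19 log units higher from compound 2 to compound 3 (within the scatter) and this small step does not separate the two compounds, so adding this one atom to the ring makes no readable difference here. Nothing measured here explains the size of either step.

The compounds shown do not separate the share of the methyl from that of the nitro within the 4-methyl-3-nitrophenyl group. They also leave open what an amine or a carboxylic acid on this phenyl ring would do to the number.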